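Pyridin-3-yl in place of 2-chlorophenyl on compound 3

The compounds below may be only part of what the source reports. "The series", "measured", "known", "first", "only" and "open" are said of these compounds alone.

Compound 3 `O=C1c2ccc(C#Cc3ccccc3Cl)nc2CCN1C1CCCC1` sits at the edge of the measured range: in an assay on HEK293 cells for displacement of a labelled ligand from metabotropic glutamate receptor 5 (Homo sapiens), with a stated time of 2 h (a lower number here means a stronger inhibitor, a higher number a weaker inhibitor), compound 3 gives only a limit, > 32000 nM, and no number. Its isopropyl counterpart compound 1 `CC(C)N1CCc2nc(C#Cc3ccccc3Cl)ccc2C1=O` gives 5680 nM in this assay, and the pyridin-2-yl analogue compound 2 `CC(C)N1CCc2nc(C#Cc3ccccn3)ccc2C1=O` gives 2740 nM. The step of a 2.1-fold lower number from compound 1 to compound 2 (0.32 log units; beyond the scatter) is modest, whereas the step of an at least 5.6-fold higher number from compound 1 to compound 3 (0.75 log units; beyond the scatter) is at least modest. Compound 4 `O=C1c2ccc(C#Cc3cccnc3)nc2CCN1C1CCCC1` carries pyridin-3-yl in place of 2-chlorophenyl on a triple-bonded carbon. Among the compounds with values here, the only measured step that bears on this change is a 2.1-fold lower number from compound 1 to compound 2 (0.32 log units; beyond the scatter), with pyridin-2-yl rather than pyridin-3-yl, so a similarly small lowering is expected. Compound 3 stands at the limit (the limit of > 32000 nM in this assay, at which 1 of the 3 values shown sits), so compound 4 may again return only a limit. The estimate for compound 4 in this assay is 18000 nM, ranging from 7000 nM to 50000 nM, which means an expected step of an at least 1.7-fold lower number from compound 3 to compound 4 (0.24 log units; that floor lies within the scatter).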

Compound 4, inhibition constant: > 32000 nM
Compound 4: a limit, no number; the forecaster's own chance of this, stated with the estimate: 45%; at least 1.7-fold (0.24 log units) between middle value and limit.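

In this assay compound 4 gives only a limit, > 32000 nM. Within the data shown here, compound 3 also gives only a limit, so no step between compound 3 and compound 4 can be read. The compounds shown leave open how far pyridin-3-yl in place of 2-chlorophenyl shifts the number on this core.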